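A few compounds are considered here, and "the series" means these few. Any claim that something is new, unique, unknown or untested is made for them only; others in the source may bear on it.

Working notes on the series. In a physicochemical assay for lipophilicity, at pH 7.4 (a higher number here means a more lipophilic compound, a lower number a more polar compound), compound 2 `CC(C)CN(c1ccc(N(C)C)cc1)S(=O)(=O)c1ccc2c(c1)C(=O)CC(C1CCOCC1)O2` gives 3.6, the second highest of the three numbers: compound 1 `CCc1ccc(N(CC(C)C)S(=O)(=O)c2ccc3c(c2)C(=O)CC(C2CCNCC2)O3)cc1` gives 2.21, and compound 3 `CCc1ccc(N(CC(C)C)S(=O)(=O)c2ccc3c(c2)C(=O)CC(C2CCN(C(=O)OC(C)(C)C)CC2)O3)cc1` gives 5.1. Among the measured compounds shown here, the one measured step, a number 2.89 log units higher from compound 1 to compound 3 (beyond the scatter), concerns the amine nitrogen in the ring and not the sulfonamide nitrogen. Compound 4 `CC(C)CN(c1ccccc1F)S(=O)(=O)c1ccc2c(c1)C(=O)CC(C1CCOCC1)O2` differs from compound 2 only at that sulfonamide nitrogen: 2-fluorophenyl in place of 4-(dimethylamino)phenyl on a sulfonamide nitrogen. For the measured compounds named here, no measured pair bears on this exchange, so the expectation rests on the change alone, with nothing in the numbers pointing either way. The step of a number 0.10 log units lower from compound 2 to compound 4 (within the scatter) is therefore expected to stay within the scatter, in no clear direction. Compound 4 is estimated at 3.5, with a range of 3 to 4.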

Compound 4, distribution coefficient: 3.44
The estimate for compound 4 lay 0.06 log units above the measured number; the measured number falls inside the stated range.
By their numbers in this assay, from the lowest: compound 1; then compounds 4 and 2 (each within the scatter of the next); then compound 3.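

Among the compounds shown here, on a sulfonamide nitrogen, 2-fluorophenyl in place of 4-(dimethylamino)phenyl gives a number 0.16 log units lower from compound 2 to compound 4 (within the scatter) in this assay, the first measured exchange at this position. The two groups cannot be told apart in this assay, even though 4-(dimethylamino)phenyl has 9 heavy atoms and 1 hydrogen-bond acceptor, and 2-fluorophenyl has 7 heavy atoms and 0 hydrogen-bond acceptors. Nothing available accounts for this result. On these data alone, it remains open whether the same exchange reads alike with the amine nitrogen in the ring of compound 1, and what a phenyl carrying a carboxylic acid would give on this sulfonamide nitrogen.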